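Ester variation at the acyl position: cytotoxicity notes

A few compounds are considered here, and "the series" means these few. Any claim that something is new, unique, unknown or untested is made for them only; others in the source may bear on it.

compound 1 `CC(=O)O[C@@H]1C=CC(=O)O[C@@H]1[C@@H](COC(=O)c1ccc(Cl)cc1)OC(C)=O`: > 100000 nM (a limit of the assay, not a number)
compound 2 `CC(=O)O[C@@H]1C=CC(=O)O[C@@H]1[C@@H](COC(=O)/C=C/c1ccc(F)cc1)OC(C)=O`: > 100000 nM (a limit of the assay, not a number)
compound 3 `CC(=O)OC[C@@H](OC(C)=O)[C@H]1OC(=O)C=C[C@H]1OC(C)=O`: not yet measured

In an ADME assay on MRC5 cells (Homo sapiens) for cytotoxicity, read by MTT assay, with a stated time of 6 days (on this read-out higher numbers stand for weaker inhibition and lower numbers for stronger inhibition), compound 1 gives > 100000 nM, which is a limit of the assay rather than a number. Compound 2 gives > 100000 nM, again a limit and not a number. Both values therefore sit at the limit of > 100000 nM in this assay, at which 2 of the 2 values shown sit, and the step that the two limits leave unreadable from compound 1 to compound 2 cannot be read in either direction or size. Going by the values given here, compound 2 thus stands at the limit, with the one further value shown being a limit as well.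

Compound 3 differs from compound 2 in one place: methyl in place of 2-(4-fluorophenyl)ethenyl on a carbonyl carbon. Among the compounds with values here, the only measured step that bears on this position, the one from compound 1 to compound 2, is unreadable, so no measured step points to a change beyond the scatter in this assay. Compound 3 is expected to give 150000 nM, with a range from 50000 nM to 500000 nM, most likely reported again as a limit. The step that the limit leaves unreadable from compound 2 to compound 3 implied by this estimate is expected to be none beyond the scatter.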

Compound 3, half-maximal inhibitory concentration: > 100000 nM
Compound 3: a limit, no number (the forecaster's own chance of this, stated with the estimate: 85%); the middle value does not contradict the limit.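

No new step can be read among compound 1, compound 2 and compound 3, since each result is a limit of the assay and not a number: the limit of > 100000 nM in this assay, at which 3 of the 3 values shown sit.

The compounds shown leave open whether any group on this carbonyl carbon of the shared core would give a readable value in this assay, and how far methyl, 4-chlorophenyl and 2-(4-fluorophenyl)ethenyl differ there.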